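Arylpiperazine propyl indole amides: alpha-1B binding notes

The compounds below may be only part of what the source reports. "The series", "measured", "known", "first", "only" and "open" are said of these compounds alone.

Measured so far:
compound 1 `COc1ccccc1N1CCN(CCCNC(=O)c2ccc3[nH]ccc3c2)CC1` 123 nM
compound 2 `COc1ccccc1N1CCN(CCCNC(=O)CCCc2c[nH]c3ccccc23)CC1` 95.5 nM
compound 3 `COc1ccccc1N1CCN(CCCNC(=O)c2cc3cccc([N+](=O)[O-])c3[nH]2)CC1` 646 nM

All three share the methoxyphenylpiperazine propylamide core and differ only in the indole-bearing part on the carbonyl carbon. In an assay on isolated protein (spleen, strain Sprague-Dawley) for antagonist activity at Alpha-1B adrenergic receptor (Rattus norvegicus), with a stated time of 20 min (on this read-out lower numbers stand for tighter binding and higher numbers for weaker binding), compound 1 gives 123 nM, the second highest of the three numbers. Compound 2, with its longer chain to the indole, gives 95.5 nM, within the scatter of compound 1. Compound 3, carrying the nitro-substituted indol-2-yl, gives 646 nM, a number well beyond the scatter above that of compound 1.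

Compound 4 `COc1ccccc1N1CCN(CCCNC(=O)c2cc3ccc(Br)cc3[nH]2)CC1` has not yet been run in this assay. Relative to compound 1 the change is 6-bromo-1H-indol-2-yl in place of 1H-indol-5-yl on a carbonyl carbon. Among the measured compounds shown here, no measured pair isolates this change. The only other indol-2-yl amide is compound 3, and its value 646 nM sits clearly above compound 1, so the expectation for compound 4 is a modestly higher number than compound 1, a step of a 2.0-fold higher number from compound 1 to compound 4 (0.31 log units; beyond the scatter) that may or may not exceed the scatter. Compound 4 is therefore estimated at 250 nM, with a plausible range from 80 nM to 800 nM.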

Compound 4, dissociation constant: 209 nM
Beside the measured number, compound 4's estimate is 1.2-fold (0.08 log units) above it, within the range that was stated.
By their numbers in this assay, from the lowest: compounds 2, 1 and 4 (each within the scatter of the next, the first and the last beyond it); then compound 3.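

In this assay, replacing 1H-indol-5-yl with 6-bromo-1H-indol-2-yl on the carbonyl carbon gives a 1.7-fold higher number from compound 1 to compound 4 (0.23 log units; within the scatter), so this read-out does not separate the two compounds. Among the compounds shown here, this is the first measured step at this place, and it shows that the bromine-bearing indol-2-yl group is compatible with a value within the scatter of compound 1. However, the exchange changes the point of attachment to the indole and adds the bromine together, so the step cannot be assigned to either change, and nothing at hand explains the result.

The compounds shown leave open how the plain 1H-indol-2-yl group would read on the same carbonyl carbon, which would separate the effect of the bromine from that of the attachment point. They also leave open whether a chlorine or a methoxy group in place of the bromine, or a longer chain between the carbonyl carbon and the 6-bromoindole, would stay within the scatter of compound 4.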